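This account rests on a few compounds, and the source may have more. Where it says the series, first, only, none or still open, it means among the compounds named here.

In a functional assay on KB cells (Homo sapiens) for antiproliferative activity, read by sulforhodamine B assay, with a stated time of 3 days (on this read-out higher numbers stand for an effect only at larger amounts of compound and lower numbers for an effect already at smaller amounts), compound 1 `CCCCOC1=C(CCC)C(=O)/C(=C(O)/C=C/c2ccccc2)C(=O)C1(CCC)CCC` gives 8 uM and compound 2 `CCCC1=C(OCC)C(CCC)(CCC)C(=O)/C(=C(O)\C=C\c2ccccc2)C1=O` gives 6.4 uM, so these two values stand within the usual scatter of each other. Compound 3 `CCCOC1=C(CCC)C(=O)/C(=C(O)/C=C/c2ccccc2)C(=O)C1(CCC)CCC` differs from compound 2 by methyl in place of hydrogen on a saturated chain carbon, two bonds along the chain from an oxygen on an unsaturated carbon, or ethoxy to propoxy. Going by the values given here, the one measured change at this place, a 1.3-fold lower number from compound 1 to compound 2 (0.10 log units; within the scatter), is small, so no step beyond the scatter is expected in this assay. The expected step is a 1.1-fold higher number from compound 2 to compound 3 (0.04 log units; within the scatter). Compound 3 is estimated at 7 uM, with an expected range of 3.5 uM to 14 uM.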

Compound 3, concentration for half-maximal effect: 2.7 uM
Compound 3: the middle estimate sits 2.6-fold (0.41 log units) above what was measured, and the stated range ends above it.
By their numbers in this assay, from the lowest: compound 3; then compounds 2 and 1 (each within the scatter of the next).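

In this assay this position proves sensitive to chain length after all: a 2.4-fold lower number from compound 2 to compound 3 (0.37 log units; beyond the scatter), and shortening the chain from the other side gives a 3.0-fold lower number from compound 1 to compound 3 (0.47 log units; beyond the scatter). The ethoxy compound 2 and the butoxy compound 1 stand within the scatter of each other, so the propoxy compound 3 stands apart from both and the three chains form no steady trend. Nothing available here explains this result. As far as these compounds go, it remains open how a hexyloxy chain, a benzyloxy group or an amine at the chain end would read out at this position.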